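This account rests on a few compounds, and the source may have more. Where it says the series, first, only, none or still open, it means among the compounds named here.

Compound 1 `Cc1ccccc1-n1nncc1CN1C(=O)C2(C(C#N)=C(N)Oc3c2c2nc4ccccc4nc2c2ccccc32)c2ccccc21` is the reference point of this small set. In a functional assay on MCF7 cells (Homo sapiens) for antiproliferative activity, read by MTT assay, with a stated time of 48 h (a higher number here means a weaker inhibitor, a lower number a stronger inhibitor), compound 1 gives only a limit of the assay, > 50000 nM. Two neighbours differ from it solely in the group on the aromatic nitrogen of the five-membered aromatic ring with 3 nitrogen. Compound 2 `N#CC1=C(N)Oc2c(c3nc4ccccc4nc3c3ccccc23)C12C(=O)N(Cc1cnnn1-c1ccc(Br)cc1)c1ccccc12` bears 4-bromophenyl there, and in this assay compound 2 gives 36600 nM, so the change reads an at least 1.3-fold lower number from compound 1 to compound 2 (0.13 log units; that floor lies within the scatter). Compound 3 `CCOc1ccccc1-n1nncc1CN1C(=O)C2(C(C#N)=C(N)Oc3c2c2nc4ccccc4nc2c2ccccc32)c2ccccc21` bears 2-ethoxyphenyl. For compound 3 this assay again reports only a limit of the assay, > 50000 nM. Accordingly a step that the two limits leave unreadable from compound 1 to compound 3, while an at least 1.3-fold higher number from compound 2 to compound 3 (0.13 log units; that floor lies within the scatter). Going by the values given here, since two of the three values sit at the limit of > 50000 nM in this assay, at which 2 of the 3 values shown sit, none of the measured steps can be called real.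

Compound 4 `N#CC1=C(N)Oc2c(c3nc4ccccc4nc3c3ccccc23)C12C(=O)N(Cc1cnnn1-c1ccc(N)cc1)c1ccccc12` is the next entry: 4-aminophenyl in place of 2-methylphenyl on an aromatic nitrogen. Among the compounds with values here, the step from compound 1 to compound 4 has no direct precedent; the closest guide is compound 2, whose 4-bromophenyl gave 36600 nM, a number that sits barely inside the measurable range. The step from compound 1 to compound 4 is therefore expected to be small or unreadable, with compound 4 estimated to remain near the limit. For compound 4 the expected value in this assay is 45000 nM, within 20000 nM to 120000 nM, which would mean an expected at least 1.1-fold lower number from compound 1 to compound 4 (0.04 log units; that floor lies within the scatter).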

Compound 4, half-maximal inhibitory concentration: > 50000 nM
Compound 4 was reported as a limit; the forecaster's own chance of this, stated with the estimate: 55%; middle value at least 1.1-fold (0.04 log units) away from the limit.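

Going by these compounds alone, the one readable step, amino in place of bromo on an aromatic carbon, is an at least 1.3-fold higher number from compound 2 to compound 4 (0.13 log units; that floor lies within the scatter), so no separation beyond the scatter can be claimed between 4-bromophenyl and 4-aminophenyl. Compared with the earlier compounds, which carried 2-methylphenyl, 2-ethoxyphenyl or 4-bromophenyl, 4-aminophenyl on the aromatic nitrogen introduces a hydrogen-bond donor and acceptor, yet it gives no readable value in this assay. The steps to compound 4 from compound 1 and from compound 3 cannot be read, as both ends of each are limits, and the set now rests largely on one such limit: the limit of > 50000 nM in this assay, at which 3 of the 4 values shown sit.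

Compound 2 remains the only compound shown with a measured number, so it stays open whether any group on this aromatic nitrogen can bring the series well inside the measurable range of this assay. A 4-chlorophenyl, a 4-carboxyphenyl or an unsubstituted phenyl at this place would test whether the value of compound 2 is tied to bromo, and a benzyl group or a longer alkyl chain would test whether an aryl group directly on the nitrogen is needed at all.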